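A Second Fluoro at the Assay Limit

The source may report more compounds than this note shows. Statements on the series, on what has been measured and on what is new or still open speak of the compounds shown alone.

In a toxicity assay on Huh-7 cells (Homo sapiens) for cytotoxicity, read by CCK-8 assay, with a stated time of 24 h (a lower number here means that less compound is tolerated, a higher number that more compound is tolerated), compound 1 `O=c1cc(-c2ccccc2)oc2c(-c3cccc(F)c3)c(O)c(O)c(O)c12` gives > 100000 nM as a limit of the assay and not a number. Compound 2 `CN1CCN(c2ccc(-c3cc(=O)c4c(O)c(O)c(O)cc4o3)cc2)CC1` gives > 100000 nM as a limit too. Compound 3 `Oc1cc2oc(-c3ccccc3)cc(=S)c2c(O)c1O` likewise gives > 100000 nM as a limit. Together they show the limit of > 100000 nM in this assay, at which 3 of the 3 values shown sit, and nothing finer. Compound 4 `O=c1cc(-c2ccccc2)oc2c(-c3cc(F)cc(F)c3)c(O)c(O)c(O)c12` carries one change on the core of compound 1, where fluoro replaces hydrogen on an aromatic carbon and turns 3-fluorophenyl into 3,5-difluorophenyl fluoro in place of hydrogen on an aromatic carbon with the rest left as it was. Going by the values given here, no measured step guides this change, so no shift beyond the scatter is expected in this assay and the estimated a number no higher from compound 1 to compound 4 (the limit leaves the size open) stays small. Compound 4 is expected at 100000 nM within an estimated range of 50000 nM to 200000 nM and may well come out only as a limit.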

Compound 4, half-maximal cytotoxic concentration: > 100000 nM
Compound 4 ended at the assay's limit; the forecaster's own chance of this, stated with the estimate: 85%; the middle value sits exactly at the limit.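

No step can be read from compound 1 to compound 4, because both values are limits and not numbers: the limit of > 100000 nM in this assay, at which 4 of the 4 values shown sit. What the compounds shown leave open is how far apart they truly lie in this assay, and whether the second fluoro changes anything there at all.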